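Swapping Ethyl for Benzyl on a Shared Core

The source may hold more compounds than are shown below. What is called first, only, known or untested is meant among the compounds shown, and "the series" means these compounds.

Of the compounds shown here, two have so far been tested in a functional assay on WI-38 VA13 cells (Homo sapiens) for cytotoxicity; on this read-out higher numbers stand for an effect only at larger amounts of compound and lower numbers for an effect already at smaller amounts. Compound 1 `CCCC(=O)Nc1nc2ccc(NC(=O)c3c(Cl)cccc3Cl)cc2s1` gives 0.01 ug/mL, and compound 2 `CCNC(=O)Nc1nc2ccc(NC(=O)c3c(Cl)cccc3Cl)cc2s1` gives 0.032 ug/mL. Among the compounds with values here, the single step between them, a 3.2-fold higher number from compound 1 to compound 2 (0.51 log units; beyond the scatter), replaced a propyl on the carbonyl carbon with an ethylamino group, so compound 2 stands with the higher of the two numbers, separated from compound 1 by a margin beyond the scatter.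

Compound 3 `O=C(NCc1ccccc1)Nc1nc2ccc(NC(=O)c3c(Cl)cccc3Cl)cc2s1` has not yet been measured. It differs from compound 2 by phenyl in place of methyl on a saturated chain carbon bound to an amide-type nitrogen; read one bond further out, this is ethylcarbamoyl becoming benzylcarbamoyl. Within the data shown here, no measured step exchanges a short chain for a phenyl-bearing one, so the only guide is that the shared core has accepted change at this part of the molecule with modest movement, as a 3.2-fold higher number from compound 1 to compound 2 (0.51 log units; beyond the scatter) shows. The expected step of a 1.1-fold lower number from compound 2 to compound 3 (0.03 log units; within the scatter) is therefore judged small, with no direction claimed beyond the scatter. For compound 3 a number of 0.03 ug/mL is expected, within a range from 0.008 ug/mL to 0.12 ug/mL.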

Compound 3, half-maximal effective concentration: 0.15 ug/mL
Compound 3: middle estimate off by 5.0-fold (0.70 log units), on the low side; measured number above the stated range.
By their numbers in this assay, from the lowest: compound 1; then compound 2; then compound 3.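

In this assay, the change from ethyl to benzyl gives a 4.7-fold higher number from compound 2 to compound 3 (0.67 log units; beyond the scatter) and so shows that this end of the molecule is not indifferent to a phenyl-bearing group: more compound is needed before the effect appears. Set against the propyl group of compound 1, the benzylamino group of compound 3 gives a 15-fold higher number from compound 1 to compound 3 (1.18 log units; beyond the scatter) and marks a large change at this single place on the shared core. Nothing measured here explains the rise.

The change from ethyl to benzyl adds both a ring and more carbon at once, so these compounds leave open which of the two goes with the higher number. A longer open chain such as hexylamino, a saturated ring such as cyclohexylmethylamino, or a benzyl group carrying a methoxy group on its ring would each test a different part of that question.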